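The source may report more compounds than this note shows. Statements on the series, on what has been measured and on what is new or still open speak of the compounds shown alone.

Measured values in a functional assay on K562 cells (Homo sapiens) for antiproliferative activity, read by MTT assay, with a stated time of 48 h; a higher number here means a weaker inhibitor, a lower number a stronger inhibitor:
compound 1 `N#CC1=C(N)Oc2cc3oc(-c4ccccc4)cc(=O)c3c(O)c2C12C(=O)N(Cc1ccccc1)c1c(Cl)cccc12` – 47800 nM
compound 2 `N#CC1=C(N)Oc2cc3oc(-c4ccccc4)cc(=O)c3c(O)c2C12C(=O)Nc1ccccc12` – 36400 nM
compound 3 `N#CC1=C(N)Oc2cc3oc(-c4ccccc4)cc(=O)c3c(O)c2C12C(=O)Nc1cc(Cl)ccc12` – 9250 nM

Compound 3 gives the lowest number of the three in this assay. Compound 2 stands nearest to it and compound 1 furthest, both higher by steps beyond the scatter. Compound 1 and compound 3 differ in more than one place, so their gap is read only as two values, not as a step.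

Compound 4 `N#CC1=C(N)Oc2cc3oc(-c4ccccc4)cc(=O)c3c(O)c2C12C(=O)Nc1cc(Br)ccc12` differs from compound 3 in one place: bromo in place of chloro on an aromatic carbon.

For the measured compounds named here, only one single-place step has been measured: a 3.9-fold lower number from compound 2 to compound 3 (0.59 log units; beyond the scatter), where chloro replaces hydrogen on an aromatic carbon. It shows that a halogen at that carbon goes with a lower number, but it does not cover exchanging one halogen for another, and no such exchange has been measured in this series. With nothing in the data to argue for a large move either way, the expected step of a 1.2-fold lower number from compound 3 to compound 4 (0.06 log units; within the scatter) is small, within the scatter, with only a slight lean toward a lower number. Compound 4 is therefore estimated at 8000 nM, with a range from 3500 nM to 20000 nM.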

Compound 4, half-maximal inhibitory concentration: 8700 nM
For compound 4 the middle estimate is 1.1-fold (0.04 log units) below the measured one; the measured number falls inside the stated range.
By their numbers in this assay, from the lowest: compounds 4 and 3 (each within the scatter of the next); then compounds 2 and 1 (each within the scatter of the next).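

In this assay, exchanging one halogen for the other on this aromatic carbon gives a 1.1-fold lower number from compound 3 to compound 4 (0.03 log units; within the scatter), so bromo and chloro cannot be told apart here, a comparison that was unavailable while chloro and hydrogen were the only groups shown at this carbon. Against hydrogen, bromo gives a 4.2-fold lower number from compound 2 to compound 4 (0.62 log units; beyond the scatter), so the lower number seen with chloro in a 3.9-fold lower number from compound 2 to compound 3 (0.59 log units; beyond the scatter) now also appears with a second halogen, although this holds only for these compounds and this one carbon. The data shown offer no explanation for either step.

On these data alone, it remains open whether a lower number at this carbon is tied to halogens at all: fluoro and iodo would extend the halogen comparison, while methyl, methoxy, an amine or a carboxylic acid would test groups of other kinds. Also open, as far as these compounds go, is whether bromo on this carbon would keep the same standing alongside the benzyl group that compound 1 carries on the amide nitrogen.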